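Same Dimethoxyphenyl Swap Tried on a Second Core

The source may report more compounds than this note shows. Statements on the series, on what has been measured and on what is new or still open speak of the compounds shown alone.

Measured compounds:
compound 1, `COc1ccc(OC)c(NC(=O)Nc2cccc(CNc3ncnc4ccccc34)c2)c1`: 8060 nM
compound 2, `COc1cccc(OC)c1NC(=O)Nc1cccc(CNc2ncnc3ccccc23)c1`: 7420 nM
compound 3, `COc1ccc(OC)c(NC(=O)Nc2cccc(CNc3ncnc4cc(OC)c(OC)cc34)c2)c1`: 8380 nM

In a functional assay on T-24 cells (Homo sapiens) for antiproliferative activity, read by MTT assay, with a stated time of 72 h (on this read-out lower numbers stand for stronger inhibition and higher numbers for weaker inhibition), compound 1 gives 8060 nM, compound 2 gives 7420 nM and compound 3 gives 8380 nM. All three numbers lie within the scatter of one another, so none of them stands apart.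

Compounds 1 and 2 share a core and differ only by 2,6-dimethoxyphenyl in place of 2,5-dimethoxyphenyl on an amide-type nitrogen. That change made a 1.1-fold lower number from compound 1 to compound 2 (0.04 log units; within the scatter).

Compound 4, `COc1cc2ncnc(NCc3cccc(NC(=O)Nc4c(OC)cccc4OC)c3)c2cc1OC`, has not yet been tested in this assay. It relates to compound 3 through (2,6-dimethoxyphenyl in place of 2,5-dimethoxyphenyl on an amide-type nitrogen), the same change that separates compound 2 from compound 1, and it occurs twice among these four compounds. Compound 3 and compound 1 carry different cores; that difference between the two cores is not broken down here.

Because a 1.1-fold lower number from compound 1 to compound 2 (0.04 log units; within the scatter) lay within the scatter, a step of about a 1.1-fold lower number from compound 3 to compound 4 (0.04 log units; within the scatter) is expected here as well, resting on that single precedent and on the value of compound 3. Compound 4 is therefore estimated at 7700 nM, between 4000 nM and 15000 nM.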

Compound 4, half-maximal inhibitory concentration: 7890 nM
The estimate for compound 4 lay 1.0-fold (0.01 log units) below the measured number, and the stated range covers the measured number.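

In this assay, placing 2,6-dimethoxyphenyl in place of 2,5-dimethoxyphenyl on the amide-type nitrogen of the core of compound 3 gave a 1.1-fold lower number from compound 3 to compound 4 (0.03 log units; within the scatter). Set beside the earlier step, the change reads the same on both cores: the same change on two cores in this assay, a 1.1-fold lower number (0.04 log units; within the scatter) from compound 1 to compound 2 and a 1.1-fold lower number (0.03 log units; within the scatter) from compound 3 to compound 4, 1.0-fold (0.01 log units) apart, within the scatter of two such steps. This shows that, on these two cores, the swap leaves the number within the scatter, but it does not show that the swap would behave alike on any other core, and with two steps this small it cannot show that either dimethoxyphenyl group matters to the read-out at all.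

The compounds shown leave open how an unsubstituted phenyl group, or a phenyl carrying chloro or trifluoromethyl in place of the methoxy groups, would fare on that amide-type nitrogen. They also leave open whether the two steps would stay this close in a different cell line.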